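From 2-Chlorophenyl to 4-Methoxyphenyl: A Small Step Expected

The compounds below may be only part of what the source reports. "The series", "measured", "known", "first", "only" and "open" are said of these compounds alone.

In a functional assay on MCF7 cells (Homo sapiens) for inhibition, read by MTT assay, with a stated time of 72 h, tested at 50 uM (on this read-out lower numbers stand for less inhibition of growth and higher numbers for more inhibition of growth at the one concentration tested), compound 1 (`C=CCc1cc(O)c(O)c(CN2CCC(CCO)CC2)c1`) gives 33.3%, compound 2 (`C=CCc1ccc(OCc2cn(-c3ccc(C#N)cc3)nn2)c(O)c1`) gives 35.6% and compound 3 (`C=CCc1ccc(OCc2cn(-c3ccccc3Cl)nn2)c(O)c1`) gives 34.3%. Compound 3 therefore stands level with both others, within the scatter. Compound 4 (`C=CCc1ccc(OCc2cn(-c3ccc(OC)cc3)nn2)c(O)c1`) carries 4-methoxyphenyl in place of 2-chlorophenyl on an aromatic nitrogen. Going by the values given here, one measured step touches this same place, with 2-chlorophenyl in place of 4-cyanophenyl: a number 1.3 percentage points lower from compound 2 to compound 3 (within the scatter). A single step is thin evidence, but it gives no reason to expect a change beyond the scatter in this assay. The expected step is a number 0.7 percentage points higher from compound 3 to compound 4 (within the scatter). The estimate for compound 4 is 35%, with an expected range from 21% to 49%.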

Compound 4, percent growth inhibition at one concentration: 57.2%
Compound 4: the middle estimate sits 22.2 percentage points below what was measured, outside the stated range (above it).
By their numbers in this assay, from the lowest: compounds 1, 3 and 2 (each within the scatter of the next); then compound 4.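

In this assay this place proves able to move the result: 4-methoxyphenyl in place of 2-chlorophenyl gives a number 22.9 percentage points higher from compound 3 to compound 4 (beyond the scatter) and methoxy in place of cyano gives a number 21.6 percentage points higher from compound 2 to compound 4 (beyond the scatter). The earlier step between the 4-cyanophenyl and 2-chlorophenyl compounds showed no such movement, so the group on this aromatic nitrogen matters, though not every swap there shifts the number. Nothing measured here explains the rise. As far as these compounds go, whether it belongs to methoxy alone stays open. An ethoxy group or an amine in place of methoxy would begin to answer that.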